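A few compounds are considered here, and "the series" means these few. Any claim that something is new, unique, unknown or untested is made for them only; others in the source may bear on it.

Compound 3, `NS(=O)(=O)c1ccc(NC(=S)Nc2ccc3ncnc(Nc4ccc(C(F)(F)F)cc4)c3c2)cc1`, gives 17100 nM in a functional assay on NCI-H1975 cells (Homo sapiens) for antiproliferative activity, read by MTT assay, with a stated time of 72 h (on this read-out lower numbers stand for stronger inhibition and higher numbers for weaker inhibition), the second highest of the three numbers recorded so far. Its nearest neighbour is compound 2, `NS(=O)(=O)c1ccc(NC(=S)Nc2ccc3ncnc(Nc4ccc(F)c(Br)c4)c3c2)cc1`, which in this assay gives 9980 nM, and the furthest is compound 1, `COc1cc2ncnc(Nc3cccc(C)c3)c2cc1OCCCCC(=O)Nc1ccc(S(N)(=O)=O)cc1`, which gives 32100 nM; both gaps to compound 3 lie within the scatter. Compound 4, `CCc1ccc(Nc2ncnc3ccc(NC(=S)Nc4ccc(S(N)(=O)=O)cc4)cc23)cc1`, differs from compound 3 by ethyl in place of trifluoromethyl on an aromatic carbon. Among the measured compounds shown here, only one measured step touches the same ring: a 1.7-fold higher number from compound 2 to compound 3 (0.23 log units; within the scatter), which replaced the whole aryl group on that nitrogen without moving the number beyond the scatter. A change confined to one substituent on that ring is therefore expected to produce no step beyond the scatter, a 1.1-fold lower number from compound 3 to compound 4 (0.06 log units; within the scatter). Compound 4 is expected at 15000 nM, between 5000 nM and 45000 nM.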

Compound 4, half-maximal inhibitory concentration: 38700 nM
The estimate for compound 4 lay 2.6-fold (0.41 log units) below the measured number; the measured number falls inside the stated range.
By their numbers in this assay, from the lowest: compounds 2, 3, 1 and 4 (each within the scatter of the next, the first and the last beyond it).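

Changing a single substituent on this ring can move the number in this assay beyond the scatter: ethyl in place of trifluoromethyl gives a 2.3-fold higher number from compound 3 to compound 4 (0.35 log units; beyond the scatter) and the earlier exchange of one whole aryl group for another did not do this. The 4-ethylphenyl group also stands apart from 3-bromo-4-fluorophenyl, with a 3.9-fold higher number from compound 2 to compound 4 (0.59 log units; beyond the scatter) in the same direction, though both steps are modest. From the compounds shown here alone, whether methyl, methoxy, chlorine or an amine at this place would track ethyl or trifluoromethyl stays open. Nothing measured here says why ethyl and trifluoromethyl differ.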